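Moving a Methoxy Group on the Benzamide Arm

The source may report more compounds than this note shows. Statements on the series, on what has been measured and on what is new or still open speak of the compounds shown alone.

Compound 1 `CNc1nc(Nc2ccc(C)c(N)c2)ncc1C(=O)Nc1cc(NC(=O)c2cccc(C(F)(F)F)c2)ccc1C` and compound 2 `CNc1nc(Nc2ccc(C)c(N)c2)ncc1C(=O)Nc1cc(NC(=O)c2ccc(OC)c(OC)c2)ccc1C` share one core and differ only in the aryl group attached to the carbonyl carbon. In an ADME assay on BaF3 cells (Mus musculus) for antiproliferative activity, read by CellTiter-Glo and CCK-8 assay, with a stated time of 72 h (a higher number here means a weaker inhibitor of growth, a lower number a stronger inhibitor of growth), compound 1 gives > 10000 nM, which is a limit of the assay rather than a number. In this assay compound 2 likewise gives > 10000 nM, again a limit and not a number. The step from one to the other, a step that the two limits leave unreadable from compound 1 to compound 2, therefore cannot be read, since (the limit of > 10000 nM in this assay, at which 2 of the 2 values shown sit). Compound 2 thus stands at that limit, with no measured number to place it more precisely.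

Compound 3 `CNc1nc(Nc2ccc(C)c(N)c2)ncc1C(=O)Nc1cc(NC(=O)c2cc(OC)cc(OC)c2)ccc1C` is the compound not yet measured, related to compound 2 by 3,5-dimethoxyphenyl in place of 3,4-dimethoxyphenyl on a carbonyl carbon. Within the data shown here, the only measured step, from compound 1 to compound 2, concerns the same carbonyl carbon, but its size is not readable, so neither a direction nor a size beyond the scatter can be taken from it. With both measured values sitting at the limit, compound 3 is expected to remain there too, estimated at 10000 nM within a range of 3000 nM to 30000 nM. The resulting step is expected to be a number no higher from compound 2 to compound 3 (the limit leaves the size open).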

Compound 3, concentration for 50% growth inhibition: > 10000 nM
Compound 3 was reported as a limit (the forecaster's own chance of this, stated with the estimate: 80%); the middle value sits exactly at the limit.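

Among these compounds, no step between compound 1, compound 2 and compound 3 can be read in this assay, because each of the three compounds gives a limit and not a number: the limit of > 10000 nM in this assay, at which 3 of the 3 values shown sit. The compounds shown leave open how strongly any of them inhibits growth, and whether the aryl group on the carbonyl carbon has any bearing on it.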